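The source may report more compounds than this note shows. Statements on the series, on what has been measured and on what is new or still open speak of the compounds shown alone.

Compound 1, `c1ccc(Cc2nc3c(N4CCNCC4)cccc3[nH]2)cc1`, in an assay on HEK293 cells for displacement of a labelled ligand from 5-hydroxytryptamine receptor 7 (Homo sapiens), read by scintillation counting (a lower number here means a stronger inhibitor, a higher number a weaker inhibitor), gives > 500 nM, which is a limit of the assay and not a number.
Compound 2, `c1ccc2cc(Cc3nc4c(N5CCNCC5)cccc4[nH]3)ccc2c1`, in this assay gives > 500 nM, again a limit.
Compound 3, `c1ccc2c(Cc3nc4cc(N5CCNCC5)ccc4[nH]3)cccc2c1`, in this assay gives > 500 nM, also a limit.

Compound 3 therefore stands together with the other two at the boundary of what this assay reports: the limit of > 500 nM in this assay, at which 3 of the 3 values shown sit. Within the data shown here, none of the three yields a number, so no measured step between them can be read, and nothing sets any of them apart from the others.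

Compound 4, `CN1CCN(c2ccc3[nH]c(Cc4cccc5ccccc45)nc3c2)CC1`, differs from compound 3 in a single place: methyl in place of hydrogen on an amine nitrogen in a ring. Among the measured compounds shown here, for the step from compound 3 to compound 4 there is no measured pair of compounds to draw on, so the expected size of the change is none beyond the scatter, in either direction; all that can be said is that compound 3 sits at a limit. For compound 4 the estimate in this assay is 1500 nM, with a range from 300 nM to 8000 nM. The step this estimate implies, a step that the limit leaves unreadable from compound 3 to compound 4, is expected to stay within the scatter, and a further limit rather than a number is the likelier outcome.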

Compound 4, inhibition constant: > 500 nM
Compound 4 ended at the assay's limit (the forecaster's own chance of this, stated with the estimate: 70%); the middle value does not contradict the limit.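

Among these compounds, compound 3 and compound 4 both end at a limit of the assay and not at a number, so the change from piperazin-1-yl to 4-methylpiperazin-1-yl gives no step that can be read: the limit of > 500 nM in this assay, at which 4 of the 4 values shown sit. The compounds shown leave open how strong an inhibitor any of them is in this assay, and whether the added methyl matters at all.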